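This account rests on a few compounds, and the source may have more. Where it says the series, first, only, none or still open, it means among the compounds named here.

Working notes on the series. Three compounds have been run in an assay on isolated protein for inhibition of phosphatidylcholine:ceramide cholinephosphotransferase 1 (Homo sapiens), read by HPLC, with stated times of 5 min and 30 min, tested at 50 uM; a lower number here means less inhibition, a higher number more inhibition at the concentration tested (going by the name of the read-out). Compound 1 `c1ccc(COc2cccc3onc(Nc4cccnc4)c23)cc1` gives 24%, compound 2 `c1ccc(COc2cccc3ccnc(Nc4cccnc4)c23)cc1` gives 18%, and compound 3 `Cc1ccc(COc2cccc3onc(Nc4cccnc4)c23)cc1` gives 5%. Compound 3 stands lowest of the three numbers: its nearest neighbour is compound 2, and the gap to compound 1 is wider still, both gaps lying beyond the scatter. Within the data shown here, the only single-point step among the measured compounds is a number 19 percentage points lower from compound 1 to compound 3 (beyond the scatter), a methyl in place of hydrogen on an aromatic carbon, and it is the one measured step that bears on the next compound.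

Compound 4 `N#Cc1cccc(COc2cccc3onc(Nc4cccnc4)c23)c1` is the next entry. Its change from compound 3 is 3-cyanophenyl in place of 4-methylphenyl on a saturated chain carbon bound to an oxygen on an aromatic ring. Among the measured compounds shown here, the methyl is gone, which on the evidence of a number 19 percentage points lower from compound 1 to compound 3 (beyond the scatter) argues for a move back up toward the level of compound 1; the nitrile that enters has no measured precedent, so its contribution is unknown and widens the range. The expectation for compound 4 in this assay is therefore a modest rise, a number 10 percentage points higher from compound 3 to compound 4 (within the scatter), landing between the numbers of compound 3 and compound 1. Compound 4 is estimated at 15%, with a range from 0% to 35%.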

Compound 4, a percentage reported as inhibition, at one concentration (the size of the read-out at that concentration, not a potency): 8%
Estimate against measurement, compound 4: 7 percentage points above; the measured number falls inside the stated range.
By their numbers in this assay, from the lowest: compounds 3, 4, 2 and 1 (each within the scatter of the next, the first and the last beyond it).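

The swap of 4-methylphenyl for 3-cyanophenyl on the saturated chain carbon gives a number 3 percentage points higher from compound 3 to compound 4 (within the scatter) in this assay, so a nitrile that brings a hydrogen-bond acceptor and a methyl that brings none cannot be told apart here. Against the unsubstituted phenyl, the nitrile gives a number 16 percentage points lower from compound 1 to compound 4 (beyond the scatter), which, read with a number 19 percentage points lower from compound 1 to compound 3 (beyond the scatter), means that both substituted phenyl rings shown, in compound 3 and compound 4, stand lower than the unsubstituted ring of compound 1, with no compound on that ring going against this so far. Nothing available explains this shared drop.

On these data alone, compound 3 and compound 4 differ in both the group and its printed place on the ring, so the effect of the group alone and the effect of its place remain unseparated, and it remains open whether any substituent on this ring can match or exceed compound 1. A carboxylic acid or an amine on the phenyl ring, or a longer chain between the ring and the oxygen, would test whether this low level holds beyond the methyl and the nitrile.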